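Removing the Ester Entirely: Propanoyl to Hydroxyl

The compounds below may be only part of what the source reports. "The series", "measured", "known", "first", "only" and "open" are said of these compounds alone.

Compound 1 `CC(=O)OC1(C(=O)Nc2ccc([N+](=O)[O-])cc2)CCCCC1` and compound 2 `CCC(=O)OC1(C(=O)Nc2ccc([N+](=O)[O-])cc2)CCCCC1` share one core and differ only in the ester chain. In a functional assay on NFS-60 cells (Mus musculus) for inhibition, read by MTT assay, with a stated time of 72 h (a lower number here means a stronger inhibitor, a higher number a weaker inhibitor), compound 1 gives 517 nM, while compound 2 gives 6.4 nM, the lowest of the two numbers; the step of an 81-fold lower number from compound 1 to compound 2 (1.91 log units; beyond the scatter) is large. Compound 3 `O=C(Nc1ccc([N+](=O)[O-])cc1)C1(O)CCCCC1` drops the ester altogether: hydrogen in place of propanoyl on an oxygen on a saturated carbon. Going by the values given here, no measured step covers loss of the whole acyl group, and the single known step ran toward a longer chain, so a higher number is expected for compound 3, a step of a 230-fold higher number from compound 2 to compound 3 (2.37 log units; beyond the scatter). Compound 3 is estimated at 1500 nM, between 150 nM and 15000 nM.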

Compound 3, half-maximal inhibitory concentration: 716 nM
Beside the measured number, compound 3's estimate is 2.1-fold (0.32 log units) above it, and the stated range covers the measured number.
By their numbers in this assay, from the lowest: compound 2; then compounds 1 and 3 (each within the scatter of the next).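

In this assay the change from propanoyloxy to hydroxy gives a 110-fold higher number from compound 2 to compound 3 (2.05 log units; beyond the scatter) and so removes the low number of compound 2. Taking off acetyl instead gives a 1.4-fold higher number from compound 1 to compound 3 (0.14 log units; within the scatter) and leaves compound 1 and compound 3 indistinguishable, so an ester on this oxygen does not by itself give a low number: here, only the propanoyl ester does. Nothing available explains why the two esters part so sharply. From the compounds shown here alone, whether a butanoyl or longer chain on this oxygen would lower the number further remains open, as does how a methyl ether there would compare with the hydroxyl.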